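Compound 3 to compound 4: piperidin-4-yl in place of methyl

The source may hold more compounds than are shown below. What is called first, only, known or untested is meant among the compounds shown, and "the series" means these compounds.

In a physicochemical assay for solubility, read by HPLC (a higher number here means a more soluble compound, a lower number a less soluble compound), compound 1 `Cc1cc2[nH]nc(N)c2c(=O)[nH]1` gives 1640 ug/mL and compound 2 `Nc1n[nH]c2cc(C3CCNCC3)[nH]c(=O)c12` gives 2340 ug/mL. Compound 3 `Cc1cc2c(c(N)nn2C)c(=O)[nH]1` gives 1220 ug/mL, within the scatter of both other numbers, so it holds no distinct place among them.

Compound 4 `Cn1nc(N)c2c(=O)[nH]c(C3CCNCC3)cc21` differs from compound 3 by piperidin-4-yl in place of methyl on an aromatic carbon. Among the compounds with values here, the only measured step is a 1.3-fold lower number from compound 1 to compound 3 (0.13 log units; within the scatter), for methyl in place of hydrogen on an aromatic nitrogen, and it does not leave the scatter. Within the data shown here, no measured step covers the exchange itself. Compound 2 also carries piperidin-4-yl, and its 2340 ug/mL stays within the scatter of compound 1 at 1640 ug/mL. No step beyond the scatter is therefore expected in this assay. The estimated step is a 1.5-fold higher number from compound 3 to compound 4 (0.17 log units; within the scatter), which would remain within the scatter. For compound 4 the expected value is 1800 ug/mL, with an estimated range of 950 ug/mL to 3400 ug/mL.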

Compound 4, solubility: > 15000 ug/mL
Compound 4: a limit, no number; the forecaster's own chance of this, stated with the estimate: 5%; middle value at least 8.3-fold (0.92 log units) away from the limit.
By their numbers in this assay, from the lowest: compounds 3, 1 and 2 (each within the scatter of the next). At a limit, above all of these: compound 4.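

In this assay, piperidin-4-yl in place of methyl on an aromatic carbon now gives a step beyond the scatter, an at least 12-fold higher number from compound 3 to compound 4 (1.08 log units; beyond the scatter), while compound 1 at 1640 ug/mL and compound 2 at 2340 ug/mL lie within the scatter of each other. Methyl in place of hydrogen on an aromatic nitrogen gives a 1.3-fold lower number from compound 1 to compound 3 (0.13 log units; within the scatter) with methyl on the aromatic carbon, but an at least 6.4-fold higher number from compound 2 to compound 4 (0.80 log units; beyond the scatter) with piperidin-4-yl there, so in these four compounds the size of each change depends on the group at the other place. The value of compound 4 is a limit of the assay and not a number: the limit of > 15000 ug/mL in this assay, at which 1 of the 4 values shown sits.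

How far compound 4 lies past that limit cannot be read from these data. Also open, as far as these compounds go, is whether the step needs the ring nitrogen of piperidin-4-yl: a cyclohexyl group or an open-chain amine on the same aromatic carbon would separate the ring from the amine.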